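Replacing the naphthyl group on the shared core

The source may hold more compounds than are shown below. What is called first, only, known or untested is meant among the compounds shown, and "the series" means these compounds.

The series is followed in an assay on isolated protein (Bos taurus) for inhibition of geranylgeranyl transferase type-1 subunit beta (Homo sapiens); a higher number here means a weaker inhibitor, a lower number a stronger inhibitor. Compound 1 `Cn1cncc1C(OCc1ccc(C#N)cc1-c1cccc2ccccc12)c1ccc(C#N)nc1` gives only a limit in this assay, > 10 nM, and no number is known for it (the limit of > 10 nM in this assay, at which 1 of the 3 values shown sits). Two further compounds on related cores carry measured values: compound 2 `Cn1cncc1C(OCc1nc(N2CCC(C(N)=O)CC2)c(C#N)cc1-c1cccc(Cl)c1)c1ccc(C#N)cc1` gives 2100 nM in this assay, and compound 3 `Cn1cncc1C(OCc1ccc(C#N)nc1-c1ccc2ccccc2c1)c1ccc(C#N)cc1` gives 5500 nM. Among the compounds with values here, compound 2 and compound 3 differ in more than one place, so their values stand as they are and no step is drawn between them.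

Compound 4 `Cn1cncc1C(OCc1ccc(C#N)cc1-c1cccc(OC(F)(F)F)c1)c1ccc(C#N)nc1` is the untested neighbour of compound 1: 3-(trifluoromethoxy)phenyl in place of naphthalen-1-yl on an aromatic carbon, ortho to a large group and meta to a cyano group. No measured step in this assay covers such a change, and compound 1 supplies only a limit as the starting point, so the direction and size of the step cannot be read from the numbers shown. The step from compound 1 to compound 4 is expected to be a step that the limit leaves unreadable from compound 1 to compound 4. The values of compound 2 and compound 3 show where measured members of the series fall. Compound 4 is estimated at 600 nM in this assay, within 60 nM to 6000 nM.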

Compound 4, half-maximal inhibitory concentration: 990 nM
The estimate for compound 4 lay 1.7-fold (0.22 log units) below the measured number; the measured number falls inside the stated range.
By their numbers in this assay, from the lowest: compound 4; then compound 2; then compound 3.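

No new step can be read from compound 1 to compound 4, because compound 1 stands only as a limit in this assay: the limit of > 10 nM in this assay, at which 1 of the 4 values shown sits.

The compounds shown leave open the direction and size of the change when 3-(trifluoromethoxy)phenyl takes the place of naphthalen-1-yl on the shared core.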